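Hydroxy in Place of Chloro on Two Related Cores

A few compounds are considered here, and "the series" means these few. Any claim that something is new, unique, unknown or untested is made for them only; others in the source may bear on it.

Measured compounds:
compound 1, `Cn1c(SCC(=O)Nn2c(COc3ccc(Cl)cc3Cl)nc3ccccc3c2=O)nc(-c2ccc(Cl)cc2)c(C#N)c1=O`: 80.8%
compound 2, `Cn1c(SCC(=O)Nn2c(COc3ccc(Cl)cc3Cl)nc3ccccc3c2=O)nc(-c2ccc(O)cc2)c(C#N)c1=O`: 76.9%
compound 3, `N#Cc1c(Cl)nc(SCC(=O)Nn2c(COc3ccc(Cl)cc3Cl)nc3ccccc3c2=O)nc1-c1ccc(Cl)cc1`: 61.5%

Three compounds were tested in a functional assay on the whole organism (strain albino) for inhibition, with Rattus norvegicus as the target, read by paw edema, with stated times of 1 h and 0.5 h, at a dose of 100 mg/kg by the oral route; a lower number here means less inhibition, a higher number more inhibition at the dose given (going by the name of the read-out). Compound 1 gives 80.8%, compound 2 gives 76.9%, and compound 3 gives 61.5%. Compound 2 differs from compound 1 by hydroxy in place of chloro on an aromatic carbon; that change gave a number 3.9 percentage points lower from compound 1 to compound 2 (within the scatter), so the two compounds are not separated by this assay. Compound 3 stands lowest of the three, beyond the scatter from both of the others; it shares the chloro-bearing phenyl of compound 1 but carries it on a different core, and the difference between the two cores is not broken down here.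

Compound 4, `N#Cc1c(Cl)nc(SCC(=O)Nn2c(COc3ccc(Cl)cc3Cl)nc3ccccc3c2=O)nc1-c1ccc(O)cc1`, has not yet been measured in this assay. It differs from compound 3 by hydroxy in place of chloro on an aromatic carbon, the same change as that between compound 1 and compound 2, at a place described in the same words. Among the compounds with values here, that earlier step, a number 3.9 percentage points lower from compound 1 to compound 2 (within the scatter), is the only guide to what this change does. The step now expected is a number 3.5 percentage points lower from compound 3 to compound 4 (within the scatter). Compound 4 is therefore expected to give about 58%, with a likely range from 46% to 70%.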

Compound 4, a percentage reported as inhibition, in the whole organism at one dose (the size of the read-out at that dose, not a potency): 67.3%
Compound 4: middle estimate off by 9.3 percentage points, on the low side; the range from low to high includes it.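

On the core of compound 3, hydroxy in place of chloro, which turns a 4-chlorophenyl into a 4-hydroxyphenyl, gave a number 5.8 percentage points higher from compound 3 to compound 4 (within the scatter) in this assay. Set beside the earlier step on the core of compound 1, the new step does not differ from it: the same change on two cores in this assay, a number 3.9 percentage points lower (within the scatter) from compound 1 to compound 2 and a number 5.8 percentage points higher (within the scatter) from compound 3 to compound 4, 9.7 percentage points apart, within the scatter of two such steps This shows that, across these two pairs, the change leaves the read-out within the scatter on both cores, so the two cores give no sign of treating it differently; it does not show a real rise on one core or a real fall on the other, and two pairs read at a single dose cannot establish that the change would behave alike on any further core in this series.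

The compounds shown leave open how other groups on that same six-membered aromatic ring, such as an amine, a methoxy or a carboxylic acid, would read in this assay. They also leave open which part of the difference between the two cores matters, for instance whether an amine in place of the chloro on the core of compound 3 would change the reading.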